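Cyano on the phenyl ring of compound 2

This account rests on a few compounds, and the source may have more. Where it says the series, first, only, none or still open, it means among the compounds named here.

Of the compounds shown here, two have been read so far in an ADME assay on microsomes from liver (Mus musculus) for metabolic stability, read by LC-MS, with NADPH named in the record, with a stated time of 60 min, tested at 1 uM, in the absence of a further agent; a lower number here means that less of the compound is left, a higher number that more of the compound is left. Compound 1 `COc1ccc(-n2c(C)nc3c(N4CC[C@@H](NC(C)=O)C4)nc(C)nc32)cc1OC` gives > 95%, which is a limit of the assay and not a number. Compound 2 `CC(=O)N[C@@H]1CCN(c2cc(C)nn3c(-c4ccccc4)c(C)nc23)C1` gives > 95%, again a limit of the assay. The series therefore stands at the limit of > 95% in this assay, at which 2 of the 2 values shown sit, and compound 2 has no exact value to start from.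

Compound 3 `CC(=O)N[C@@H]1CCN(c2cc(C)nn3c(-c4ccc(C#N)cc4)c(C)nc23)C1` differs from compound 2 by cyano in place of hydrogen on an aromatic carbon, para to a large group, turning phenyl into 4-cyanophenyl: cyano in place of hydrogen on an aromatic carbon. Among the measured compounds shown here, no measured pair shows a change of this kind, so the expectation is cautious. In this assay, the expected step is a number at least 2 percentage points lower from compound 2 to compound 3 (that floor lies within the scatter), which is none beyond the usual scatter. For compound 3 the estimated value is 93%, with an expected range of 78% to 100%.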

Compound 3, percent of the compound remaining: > 95%
Compound 3: no number, only a limit; the forecaster's own chance of this, stated with the estimate: 45%; middle value at least 2 percentage points away from the limit.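

No step from compound 2 to compound 3 can be read in this assay, because both values are limits of the assay and not numbers: the limit of > 95% in this assay, at which 3 of the 3 values shown sit.

The compounds shown leave open whether cyano in place of hydrogen on an aromatic carbon changes the percent remaining at all.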